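Moving a hydroxyphenyl group in the fluorophenyl series

A few compounds are considered here, and "the series" means these few. Any claim that something is new, unique, unknown or untested is made for them only; others in the source may bear on it.

Three compounds share one core: compound 1 `Oc1ccccc1-c1cc(-c2ccccc2F)cc(-c2ccccc2O)n1`, compound 2 `Oc1ccccc1-c1cc(-c2cccc(F)c2)cc(-c2ccccc2O)n1` and compound 3 `Oc1ccccc1-c1cc(-c2ccc(F)cc2)cc(-c2ccccc2O)n1`. In a functional assay on DU-145 cells (Homo sapiens) for inhibition (a lower number here means a stronger inhibitor, a higher number a weaker inhibitor), compound 1 gives > 50000 nM, which is a limit. Compound 2 gives > 50000 nM, also a limit. Compound 3 gives > 50000 nM, again a limit. Compound 2 therefore has no number of its own, and the whole set stands at one reading: the limit of > 50000 nM in this assay, at which 3 of the 3 values shown sit.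

The next structure is compound 4 `Oc1cccc(-c2cc(-c3cccc(F)c3)cc(-c3ccccc3O)n2)c1`, which carries 3-hydroxyphenyl in place of 2-hydroxyphenyl on an aromatic carbon next to the ring nitrogen: 3-hydroxyphenyl in place of 2-hydroxyphenyl on an aromatic carbon.

The measured steps are a step that the two limits leave unreadable from compound 1 to compound 2, a step that the two limits leave unreadable from compound 1 to compound 3 and a step that the two limits leave unreadable from compound 2 to compound 3. All three change the fluorophenyl group and none changes a hydroxyphenyl group, so they offer no size to carry over. The direction in this assay can only be a tentative expectation: a readable number for compound 4 would mean stronger inhibition, though another limit remains about as likely. The expected change is an at least 1.6-fold lower number from compound 2 to compound 4 (0.22 log units; that floor lies within the scatter), an estimate with wide uncertainty. For compound 4 the estimated value is 30000 nM, with an expected range of 6000 nM to 80000 nM.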

Compound 4, half-maximal inhibitory concentration: > 50000 nM
Compound 4: only a limit was reported; the forecaster's own chance of this, stated with the estimate: 50%; middle value at least 1.6-fold (0.22 log units) away from the limit.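

In this assay compound 4 gives > 50000 nM, which is a limit. The step between compound 2 and compound 4 therefore cannot be read, and the set stays at a single reading: the limit of > 50000 nM in this assay, at which 4 of the 4 values shown sit. The compounds shown leave open whether any hydroxyphenyl or fluorophenyl placement on the shared core gives a readable number in this assay.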